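The source may report more compounds than this note shows. Statements on the series, on what has been measured and on what is new or still open speak of the compounds shown alone.

Measured compounds in a functional assay on HepG2 cells (Homo sapiens) for antiproliferative activity, read by MTT assay, with a stated time of 72 h; on this read-out higher numbers stand for weaker inhibition and lower numbers for stronger inhibition:
- Compound 1 `O=C1COc2ccc(-c3cnc(Cl)c(NS(=O)(=O)c4ccc(F)cc4)c3)cc2N1c1ccccc1`: 35700 nM
- Compound 2 `COc1cccc(N2C(=O)COc3ccc(-c4cnc5ccccc5c4)cc32)c1`: 2080 nM
- Compound 3 `COc1ncc(-c2ccc3c(c2)N(C2CCCCC2)C(=O)CO3)cc1NS(=O)(=O)c1ccc(F)cc1`: a limit, > 40000 nM

Of the two numbers on hand, compound 1 has the higher one, so it is the weaker inhibitor of the pair. Compound 2 gives 2080 nM, well apart from compound 1 and beyond the usual scatter, though the two differ in several places at once and so show nothing about a single change. Going by the values given here, for compound 3 this assay reports only a limit, > 40000 nM, not a number; it is the one value here that sits at the limit of > 40000 nM in this assay, at which 1 of the 3 values shown sits.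

Compound 4 `Cc1ccc(N2C(=O)COc3ccc(-c4cnc(Cl)c(NS(=O)(=O)c5ccc(F)cc5)c4)cc32)cc1` is the unmeasured partner of compound 1. The change is methyl in place of hydrogen on an aromatic carbon: a methyl enters where hydrogen stood, on an aromatic carbon of a six-membered aromatic ring of carbon only, para to a large group. Among the compounds with values here, no measured pair here isolates that change, so nothing on hand tells how much it matters. A methyl is a small addition, and the expectation is a step from compound 1 to compound 4 of a 1.3-fold lower number from compound 1 to compound 4 (0.11 log units; within the scatter), which is not beyond the scatter. Compound 4 is therefore estimated at 28000 nM, with a likely range from 9000 nM to 80000 nM.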

Compound 4, half-maximal inhibitory concentration: 39600 nM
Compound 4: middle estimate off by 1.4-fold (0.15 log units), on the low side, and the stated range covers the measured number.
By their numbers in this assay, from the lowest: compound 2; then compounds 1 and 4 (each within the scatter of the next). At a limit, above all of these: compound 3.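

Going by these compounds alone, compounds 1 and 4 offer the only comparison here that changes a single place, and in this assay going from phenyl to 4-methylphenyl gives a 1.1-fold higher number from compound 1 to compound 4 (0.05 log units; within the scatter). So a methyl at this position, para to a large group, makes no difference that can be told from repeat scatter. This flat step may say little about any loss of activity, because the read-out has little room left before the limit that compound 3 reaches, which is a limit and not a number: the limit of > 40000 nM in this assay, at which 1 of the 4 values shown sits.

As far as these compounds go, what other groups do at this position stays open, such as an amine, a carboxylic acid or a longer chain. Also open, from the compounds shown here alone, is whether the same methyl would matter on the background of compound 2, which gives 2080 nM, where there is far more room to see a loss.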